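A Second Methyl on the Unsaturated Amide Chain

The source may hold more compounds than are shown below. What is called first, only, known or untested is meant among the compounds shown, and "the series" means these compounds.

Measured compounds:
Compound 1, `C=CC(=O)Nc1cccc(Oc2nc(Nc3cccc(OC)c3)nc3ccsc23)c1`, gives 16400 nM in a functional assay on HeLa cells (Homo sapiens) for inhibition, read by MTT assay, with a stated time of 72 h; a lower number here means a stronger inhibitor, a higher number a weaker inhibitor.
Compound 2, `C/C=C/C(=O)Nc1cccc(Oc2nc(Nc3cccc(OC)c3)nc3ccsc23)c1`, gives 20100 nM in this assay.

Compound 2 holds the highest of the two numbers seen so far, but its nearest neighbour, compound 1, lies within the scatter of it, so the two cannot be ordered on these data. The new compound, compound 3, `COc1cccc(Nc2nc(Oc3cccc(NC(=O)C=C(C)C)c3)c3sccc3n2)c1`, differs from compound 2 in one place: 2-methylprop-1-en-1-yl in place of prop-1-en-1-yl on a carbonyl carbon.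

Among the compounds with values here, only one measured step speaks to this kind of change. Going from vinyl to prop-1-en-1-yl on the same carbonyl carbon gave a 1.2-fold higher number from compound 1 to compound 2 (0.09 log units; within the scatter), a shift that stays within the scatter. Adding a further carbon at the same end of the chain is therefore expected to move the number little, if at all, with any drift more likely towards a higher number than a lower one. The step is estimated as a 1.2-fold higher number from compound 2 to compound 3 (0.08 log units; within the scatter). Compound 3 is accordingly expected to give about 24000 nM in this assay, with a plausible range from 9000 nM to 65000 nM.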

Compound 3, half-maximal inhibitory concentration: 26100 nM
Estimate against measurement, compound 3: 1.1-fold (0.04 log units) below, within the range that was stated.
By their numbers in this assay, from the lowest: compounds 1, 2 and 3 (each within the scatter of the next).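

In this assay, putting 2-methylprop-1-en-1-yl in place of prop-1-en-1-yl on the carbonyl carbon gives a step that stays within the scatter (a 1.3-fold higher number from compound 2 to compound 3 (0.11 log units; within the scatter)). The earlier pair offered a single step, whereas the series now also spans the widest change available here, from vinyl to 2-methylprop-1-en-1-yl, and that step also stays within the scatter (a 1.6-fold higher number from compound 1 to compound 3 (0.20 log units; within the scatter)). Across these three alkenyl groups on the carbonyl carbon of the amide, the read-out therefore gives no detectable response, and the compounds cannot be ordered. Nothing available accounts for this flat result.

From the compounds shown here alone, what remains open is whether any group at this position would move the number beyond the scatter, for example an amine carried on the alkene, a carboxylic acid, or a longer chain. It is also unresolved whether the double bond itself matters, which a saturated ethyl group on the carbonyl carbon would test, and whether the same flat picture would hold in cells other than those used here.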